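Dimethylamino in place of piperazin-1-yl: notes on compound 4

The source may report more compounds than this note shows. Statements on the series, on what has been measured and on what is new or still open speak of the compounds shown alone.

Measured in a toxicity assay on HEK-293T cells (Homo sapiens) for cytotoxicity, read by MTT assay, with a stated time of 72 h; on this read-out higher numbers stand for weaker inhibition and lower numbers for stronger inhibition:
compound 1 `CN(C)CCCCCn1c2c(c3ccccc31)C(=O)c1c[n+]([O-])c3ccccc3c1C2=O` gives 70 nM
compound 2 `O=C1c2c[n+]([O-])c3ccccc3c2C(=O)c2c1c1ccccc1n2Cc1cn(CC(O)CO)nn1` gives 760 nM
compound 3 `O=C1c2c[n+]([O-])c3ccccc3c2C(=O)c2c1c1ccccc1n2CCCCN1CCNCC1` gives 760 nM

Compound 3 shares the top of this small range, with no change at the digits printed from compound 2 to compound 3 (within the scatter). Next comes compound 4 `CN(C)CCCCn1c2c(c3ccccc31)C(=O)c1c[n+]([O-])c3ccccc3c1C2=O`, with dimethylamino in place of piperazin-1-yl on a saturated chain carbon, four bonds along the chain from an aromatic nitrogen. This places dimethylamino in place of piperazin-1-yl on a saturated chain carbon, four bonds along the chain from an aromatic nitrogen. The closest evidence is an 11-fold higher number from compound 1 to compound 3 (1.04 log units; beyond the scatter). Among the compounds with values here, compound 1 also carries dimethylamino, but its chain differs from that of compound 4, and it is the only such comparison. Most of that large step, read in reverse, is therefore expected to return in this assay, towards a lower number. The expected change is a 5.8-fold lower number from compound 3 to compound 4 (0.77 log units; beyond the scatter). For compound 4 the estimated value is 130 nM, with an expected range of 45 nM to 380 nM.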

Compound 4, half-maximal inhibitory concentration: 520 nM
The estimate for compound 4 lay 4.0-fold (0.60 log units) below the measured number; measured number above the stated range.
By their numbers in this assay, from the lowest: compound 1; then compounds 4, 2 and 3 (each within the scatter of the next).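

In this assay, dimethylamino in place of piperazin-1-yl at this place gives a 1.5-fold lower number from compound 3 to compound 4 (0.16 log units; within the scatter), so this exchange on its own does not reach the low number of compound 1. The change from the triazole-bearing side chain gives a 1.5-fold lower number from compound 2 to compound 4 (0.16 log units; within the scatter). Within the data shown here, the one step beyond the scatter is a 7.4-fold higher number from compound 1 to compound 4 (0.87 log units; beyond the scatter), with dimethylamino in place of (dimethylamino)methyl, which points to chain length rather than the terminal amine as the difference that counts here.

No evidence on hand accounts for these steps. On these data alone, whether a longer chain ending in piperazin-1-yl or in morpholine would match compound 1 stays open.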